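Adding an Amino Group to Two Chloromethyl Benzyl Purines

The source may hold more compounds than are shown below. What is called first, only, known or untested is meant among the compounds shown, and "the series" means these compounds.

Compound 1 `ClCc1ccc(Cn2cnc3c(Cl)ncnc32)cc1` and compound 3 `ClCc1ccccc1Cn1cnc2c(Cl)ncnc21` are built from the same atoms joined differently; the difference between the two cores is not broken down here. In a functional assay on 786-0 cells (Homo sapiens) for cytotoxicity, read by sulforhodamine B assay, with a stated time of 48 h (a lower number here means a stronger inhibitor of growth, a higher number a weaker inhibitor of growth), compound 1 gives 1020 nM, while compound 3 gives 17800 nM, the highest number among the three measured compounds. Compound 2 `Nc1nc(Cl)c2ncn(Cc3ccc(CCl)cc3)c2n1` arises from compound 1 by a single change, (amino in place of hydrogen on an aromatic carbon), and in this assay compound 2 gives 5250 nM. The step of a 5.1-fold higher number from compound 1 to compound 2 (0.71 log units; beyond the scatter) thus weakened growth inhibition. Compound 4 `Nc1nc(Cl)c2ncn(Cc3ccccc3CCl)c2n1` has not yet been measured. It arises from compound 3 by the same change, (amino in place of hydrogen on an aromatic carbon), and the place is described in the same words. The expectation for compound 4 rests on that one earlier example: because a 5.1-fold higher number from compound 1 to compound 2 (0.71 log units; beyond the scatter) was modest, for compound 4 a step of roughly the same size is expected, a 4.5-fold higher number from compound 3 to compound 4 (0.65 log units; beyond the scatter). With a single precedent the range must be wide. Compound 4 is therefore estimated at 80000 nM, with a likely span from 30000 nM to 200000 nM.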

Compound 4, concentration for 50% growth inhibition: 17000 nM
Estimate against measurement, compound 4: 4.7-fold (0.67 log units) above; measured number below the stated range.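

In this assay, placing an amino group on the aromatic carbon in place of hydrogen gives a 1.0-fold lower number from compound 3 to compound 4 (0.02 log units; within the scatter), so on this core the change leaves the two values indistinguishable. The same change therefore does not carry over with the same size from one core to the other, and the step measured on the core of compound 1 cannot serve as a general rule for this series: the same change on two cores in this assay, a 5.1-fold higher number (0.71 log units; beyond the scatter) from compound 1 to compound 2 and a 1.0-fold lower number (0.02 log units; within the scatter) from compound 3 to compound 4, 5.4-fold (0.73 log units) apart, beyond the scatter of two such steps

For the compounds shown here, what this does not show is why the two cores respond differently, or what the change would do on any further core, since each core supplies only a single pair of compounds. The compounds shown leave open whether a different group in the same place, such as a methylamino group or a hydroxyl group, would also depend on the core. They also leave open whether a longer chain in place of the chloromethyl group would alter the difference between the two cores.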